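The source may report more compounds than this note shows. Statements on the series, on what has been measured and on what is new or still open speak of the compounds shown alone.

Three compounds share a core in which an aromatic ring bearing a fluoronaphthyl group is joined, through a saturated chain carbon, to a five-membered ring with two heteroatoms. Compound 1 `C/C(=C1/OC(=O)NC1=O)C(c1ccc(-c2ccc3cccc(F)c3c2)[nH]c1=O)C(C)C` gives 17 nM in an assay on membranes from Chem-1 cells for displacement of a labelled ligand from prostaglandin E2 receptor EP3 subtype (Homo sapiens), read by scintillation counting, with a stated time of 2 h; a higher number here means a weaker inhibitor, a lower number a stronger inhibitor. Compound 2 `O=C1NC(=O)/C(=C/C(c2ccc(-c3ccc4cccc(F)c4c3)[nH]c2=O)C2CC2)O1` gives 22 nM in the same test, and compound 3 `CC(C)C(c1ccc(-c2ccc3cccc(F)c3c2)[nH]c1=O)C1C(=O)NC(=O)N1C` gives 46 nM. On these numbers compound 2 stands second highest of the three: its value and that of compound 1 lie within the usual scatter of each other, while the number for compound 3 is clearly higher. For the measured compounds named here, the only single-place step measured here, a 2.7-fold higher number from compound 1 to compound 3 (0.43 log units; beyond the scatter), concerns the heterocyclic ring rather than the side group.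

Compound 4 `O=C1NC(=O)/C(=C/C(Cc2ccccc2)c2ccc(-c3ccc4cccc(F)c4c3)[nH]c2=O)O1` differs from compound 2 by benzyl in place of cyclopropyl on a saturated chain carbon bound to an aromatic carbon and a double-bonded chain carbon. No measured step touches this position, so nothing shown here tells how a benzyl group behaves there; the pair compound 1 and compound 2, which differ at that carbon among other places, show values within the scatter of each other. The expectation for compound 4 is therefore a number close to that of compound 2, with wide uncertainty, amounting to a 1.4-fold higher number from compound 2 to compound 4 (0.13 log units; within the scatter). Compound 4 is estimated to give 30 nM, within a range from 10 nM to 100 nM.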

Compound 4, inhibition constant: 33 nM
Estimate against measurement, compound 4: 1.1-fold (0.04 log units) below; the measured number falls inside the stated range.
By their numbers in this assay, from the lowest: compounds 1, 2, 4 and 3 (each within the scatter of the next, the first and the last beyond it).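

In this assay, for the compounds shown here, benzyl in place of cyclopropyl on a saturated chain carbon bound to an aromatic carbon and a double-bonded chain carbon gives a 1.5-fold higher number from compound 2 to compound 4 (0.18 log units; within the scatter), and this is the first step that changes this group alone. It shows that benzyl, with its six-membered aromatic ring, can take the place of cyclopropyl, with its three-membered ring, with no difference that can be told from the normal spread of repeated measurements, although this single pair cannot show how far that holds for other groups. Nothing given here accounts for why the two compounds read so alike.

Cyclopropyl and benzyl are both made only of carbon and hydrogen, with no hydrogen-bond donors or acceptors and no net charge, so the compounds shown leave open what an amine, a carboxylic acid or a hydroxyl group would do on this carbon. They also leave open whether a longer chain, such as n-hexyl, or a larger group, such as 2-naphthylmethyl, would stay as close to compound 2.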